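A Cyanopyridyl in Place of a Hydroxyphenyl

A few compounds are considered here, and "the series" means these few. Any claim that something is new, unique, unknown or untested is made for them only; others in the source may bear on it.

Of the compounds shown here, three built on one shared core have been measured in a functional assay on HEK293 cells for agonist activity at D(4) dopamine receptor (Homo sapiens), read by FLIPR; a lower number here means that less compound is needed, a higher number that more compound is needed for the effect. Compound 1 `Cc1cccc(NC(=O)CN2CCC(c3ccc(O)cc3)CC2)c1` gives 70 nM, the lowest of the three numbers. Compound 3 `Cc1cccc(C)c1NC(=O)CN1CCC(c2cccc[n+]2[O-])CC1` gives 346 nM, and compound 2 `O=C(CN1CCC(c2cccc[n+]2[O-])CC1)Nc1cccc(-c2ccccc2)c1` gives 360 nM; both gaps to compound 1 lie beyond the scatter, so compound 1 is the most potent of the three. Compound 4 `Cc1cccc(NC(=O)CN2CCC(c3cccc(C#N)n3)CC2)c1` has not yet been measured. It differs from compound 1 in one place: 6-cyanopyridin-2-yl in place of 4-hydroxyphenyl on a saturated ring carbon. Within the data shown here, no measured pair shows this exact change, so its size cannot be read off directly. For compound 4 a moderate loss is expected, a step of a 3.1-fold higher number from compound 1 to compound 4 (0.50 log units; beyond the scatter) in this assay. The estimate for compound 4 is 220 nM, with a range from 55 nM to 900 nM.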

Compound 4, half-maximal effective concentration: 36 nM
For compound 4 the middle estimate is 6.1-fold (0.79 log units) above the measured one, and the stated range ends above it.
By their numbers in this assay, from the lowest: compounds 4 and 1 (each within the scatter of the next); then compounds 3 and 2 (each within the scatter of the next).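

In this assay, the saturated ring carbon accepts 6-cyanopyridin-2-yl in place of 4-hydroxyphenyl with a 1.9-fold lower number from compound 1 to compound 4 (0.29 log units; within the scatter), so the two groups cannot be told apart by this read-out. The hydrogen-bond donor counted on 4-hydroxyphenyl is therefore not needed for activity in this pair, where a nitrile-bearing ring with no such donor serves as well. Nothing measured here explains this match. On these data alone, it remains open whether the nitrile itself matters, which a plain pyridine ring or one carrying an amine instead could test.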